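The source may hold more compounds than are shown below. What is called first, only, known or untested is meant among the compounds shown, and "the series" means these compounds.

Compound 1, `O=C(c1cccc(F)c1)N1CC(c2nc(-c3cccc(Cl)c3)no2)C1`, in an assay on HEK293 cells for positive allosteric modulation of metabotropic glutamate receptor 5 (Homo sapiens), read by FLIPR (on this read-out lower numbers stand for an effect already at smaller amounts and higher numbers for an effect only at larger amounts of compound), gives > 10000 nM, which is a limit of the assay rather than a number.
Compound 2, `Cc1cccc(-c2noc(C3CN(C(=O)c4cccc(F)c4)C3)n2)c1`, gives > 10000 nM in this assay, again only a limit.

Compound 1 therefore stands at the edge of what this assay can read, and no number places it. For the measured compounds named here, the one measured step, a step that the two limits leave unreadable from compound 1 to compound 2, cannot be sized, since (the limit of > 10000 nM in this assay, at which 2 of the 2 values shown sit). Compound 3, `O=C(C1CCC2(CCC2)CC1)N1CC(c2nc(-c3cccc(Cl)c3)no2)C1`, differs from compound 1 in that (a group of 9 heavy atoms (9 carbon; one four-membered non-aromatic ring of carbon only, one six-membered non-aromatic ring of carbon only) in place of a group of 7 heavy atoms (6 carbon, 1 fluorine; one six-membered aromatic ring of carbon only), on a carbonyl carbon). Going by the values given here, none of the measured steps touches the carbonyl substituent, so the step from compound 1 to compound 3 has no measured counterpart; the only guidance is that compound 1 and compound 2 both sit at the limit, so compound 3 starts from an unreadable position and most outcomes remain open. With that in mind, compound 3 is expected to show 5000 nM in this assay, within a range of 500 nM to 10000 nM. The step that this estimate implies, an at least 2.0-fold lower number from compound 1 to compound 3 (0.30 log units; that floor lies within the scatter), is itself only an expectation, and a further limit is held to be the more likely result.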

Compound 3, half-maximal effective concentration: 1100 nM
Estimate against measurement, compound 3: 4.5-fold (0.66 log units) above, and the stated range covers the measured number.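

In this assay, the carbonyl substituent turns out to be a place where a single change brings a compound within reach of the read-out: replacing the 3-fluorophenyl on the carbonyl carbon with the group holding one four-membered and one six-membered non-aromatic ring of carbon only gives an at least 9.0-fold lower number from compound 1 to compound 3 (0.95 log units; beyond the scatter). Going by these compounds, this is only a floor on the size of the change, since its starting point is a limit and not a number, and the true distance between the two compounds stays unknown. Compound 3 keeps everything else from compound 1, including the 3-chlorophenyl end, so an aromatic ring on that carbonyl carbon is shown not to be needed for a readable value, and compound 3 is the one compound here that leaves the limit: the limit of > 10000 nM in this assay, at which 2 of the 3 values shown sit.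

The compounds shown leave open which part of the new group carries the step, since a plain cyclohexyl without the four-membered ring, or a longer alkyl chain, would separate the two rings' contributions. They also leave open whether methyl in place of chloro on the aromatic carbon, unreadable between the two limit compounds, would matter once it is set on compound 3.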